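Swapping a fluoropyrazole for ethoxy on the shared core

This account rests on a few compounds, and the source may have more. Where it says the series, first, only, none or still open, it means among the compounds named here.

Compound 2 `Cc1cc(C(=O)NNS(=O)(=O)c2ccccc2F)cc(-n2cc(F)cn2)c1` carries a 4-fluoro-1H-pyrazol-1-yl group on its six-membered carbon ring. For the measured compounds named here, in an ADME assay on microsomes from liver (Homo sapiens) for metabolic stability, read by HPLC, using NADPH, with a stated time of 60 min, tested at 1 uM, in the presence of a further agent that is not named here (a lower number here means slower removal, a higher number faster removal of the compound), compound 2 gives 143 uL/min, the higher of the two numbers recorded; its only neighbour is compound 1 `Cc1cc(OC(C)C)cc(C(=O)NNS(=O)(=O)c2ccccc2F)c1`, for which this assay gives 58 uL/min. Going by the values given here, the one measured step runs a 2.5-fold higher number from compound 1 to compound 2 (0.39 log units; beyond the scatter). Compound 3 `CCOc1cc(C)cc(C(=O)NNS(=O)(=O)c2ccccc2F)c1` is compound 2 changed in one place: ethoxy in place of 4-fluoro-1H-pyrazol-1-yl on an aromatic carbon. Among the compounds with values here, this reverses the one measured step in kind, removing the 4-fluoro-1H-pyrazol-1-yl group and installing an alkoxy group, though ethoxy rather than isopropoxy, so the step from compound 1 to compound 2 is the only evidence that bears on it. The number for compound 3 is therefore expected to fall back toward that of compound 1, by a 2.2-fold lower number from compound 2 to compound 3 (0.34 log units; beyond the scatter). The estimate for compound 3 in this assay is 65 uL/min, within a range of 35 uL/min to 120 uL/min.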

Compound 3, intrinsic clearance in a liver preparation (reported as CLH), per the amount of preparation that the assay uses: 181 uL/min
Compound 3: middle estimate off by 2.8-fold (0.44 log units), on the low side; the measured number lies above the stated range.
By their numbers in this assay, from the lowest: compound 1; then compounds 2 and 3 (each within the scatter of the next).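

In this assay, ethoxy and 4-fluoro-1H-pyrazol-1-yl on this aromatic carbon cannot be told apart (a 1.3-fold higher number from compound 2 to compound 3 (0.10 log units; within the scatter)), so an oxygen-linked chain at this place does not by itself go with the low number of compound 1. The difference lies within the chain: turning isopropoxy into ethoxy, with hydrogen in place of a single methyl, gives a step beyond the scatter (a 3.1-fold higher number from compound 1 to compound 3 (0.49 log units; beyond the scatter)). Nothing measured here bears on the reason for this sensitivity.

This reading rests on a single pair of alkoxy compounds, so it cannot yet be called a trend. Going by these compounds, how a methoxy group, a longer chain such as propoxy, or an amine at this place would read in this assay remains open.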